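Configuration and amide substituent in an SW480 cytotoxicity series

The source may hold more compounds than are shown below. What is called first, only, known or untested is meant among the compounds shown, and "the series" means these compounds.

Measured in a functional assay on SW480 cells (Homo sapiens) for cytotoxicity, read by MTT assay, with a stated time of 48 h; a higher number here means a weaker inhibitor, a lower number a stronger inhibitor:
compound 1 `CCOC(=O)[C@@]1(C(=O)Nc2ccccc2)C[C@@H]1c1cc(OC)c(OC)c(OC)c1` gives > 100000 nM (a limit)
compound 2 `CCOC(=O)[C@]1(C(=O)Nc2ccccc2)C[C@@H]1c1cc(OC)c(OC)c(OC)c1` gives 31700 nM
compound 3 `CCOC(=O)[C@@]1(C(=O)NCc2ccc(C)cc2)C[C@H]1c1cc(OC)c(OC)c(OC)c1` gives > 100000 nM (a limit)

In this assay compound 3 stands at a limit of the assay and not at a number (> 100000 nM). That places it at the shared limit (the limit of > 100000 nM in this assay, at which 2 of the 3 values shown sit).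

Compound 4 (`CCOC(=O)[C@@]1(C(=O)Nc2ccccc2)C[C@H]1c1cc(OC)c(OC)c(OC)c1`) keeps the configuration as drawn of compound 3 and changes the amide substituent (phenyl in place of 4-methylbenzyl on an amide-type nitrogen), with phenyl in place of 4-methylbenzyl on an amide-type nitrogen. Among the measured compounds shown here, no measured step isolates this change. For the measured compounds named here, the one measured step that bears on it concerns two compounds already carrying phenyl on that nitrogen, which differ only in configuration as drawn (the fact that compounds 1 and 2 differ only in the configuration as drawn). That step is modest (an at least 3.1-fold lower number from compound 1 to compound 2 (0.49 log units; beyond the scatter)). Compound 2 reaches a number (31700 nM). Phenyl alone does not secure a number, and compound 1 remains at a limit (> 100000 nM).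

A large gain is therefore not expected, and compound 4 may well stay at the limit. At most a modest fall in the number is expected. The expected step is (an at least 1.4-fold lower number from compound 3 to compound 4 (0.15 log units; that floor lies within the scatter)). For compound 4 the estimated value is 70000 nM, with an expected range from 20000 nM to 150000 nM.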

Compound 4, half-maximal inhibitory concentration: > 100000 nM
Compound 4 gave a limit, no number (the forecaster's own chance of this, stated with the estimate: 55%); at least 1.4-fold (0.15 log units) between middle value and limit.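

In this assay, inverting both stereocentres of compound 2 gives an at least 3.1-fold higher number from compound 2 to compound 4 (0.49 log units; beyond the scatter), so among these phenyl amides the number reached by compound 2 depends on configuration alone: the fact that compounds 2 and 4 differ only in the configuration as drawn. Compound 4 stands at a limit of the assay, > 100000 nM, so phenyl in place of 4-methylbenzyl on an amide-type nitrogen brought no measurable number in this configuration. The steps to compound 4 from compound 3 and from compound 1 cannot be read, as both ends of each are limits, and this limit now holds most of the series: the limit of > 100000 nM in this assay, at which 3 of the 4 values shown sit.

The compounds shown leave open whether 4-methylbenzyl on that nitrogen would reach a number in the configuration of compound 2, and how the remaining arrangement of the two stereocentres would behave with phenyl. They also leave open whether a carboxylic acid in place of the ester, or a longer chain between the amide-type nitrogen and the aromatic ring, would move the value of compound 2 in either direction.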